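The source may report more compounds than this note shows. Statements on the series, on what has been measured and on what is new or still open speak of the compounds shown alone.

Of the compounds shown here, two from this study have been measured in an ADME assay on microsomes from liver (Homo sapiens) for metabolic stability, with a stated time of 60 min, tested at 1 uM; on this read-out higher numbers stand for a more stable compound and lower numbers for a less stable compound. Compound 1 `Cn1cc(-c2nc3c(-c4ccnc(OC5CC5)c4)cnn3cc2OCC(C)(C)O)cn1` gives 53% in this assay. Compound 2 `COc1cc(-c2cnn3cc(OC)c(-c4cc(C)no4)nc23)ccn1` gives 31% in this assay, the lower of the two numbers, with compound 1 standing a clear step above it, beyond the usual scatter. Compound 3 `COc1cc(-c2cnn3cc(OC)c(C(C)C)nc23)ccn1` has not yet been measured. It differs from compound 2 at one place: isopropyl in place of 3-methyl-1,2-oxazol-5-yl on an aromatic carbon. Going by the values given here, no pair of measured compounds shows what such an exchange does in this assay, so the expectation rests on compound 2 alone. A small step is expected in this assay, slightly downward if anything, and quite possibly none beyond the scatter. Compound 3 is expected to give about 26% in this assay, within a range from 10% to 45%. The expected step is a number 5 percentage points lower from compound 2 to compound 3 (within the scatter).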

Compound 3, percent of the compound remaining: 40%
Compound 3: middle estimate off by 14 percentage points, on the low side, and the stated range covers the measured number.
By their numbers in this assay, from the lowest: compounds 2 and 3 (each within the scatter of the next); then compound 1.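

Exchanging the 3-methyl-1,2-oxazol-5-yl on this aromatic carbon for isopropyl gives, in this assay, a number 9 percentage points higher from compound 2 to compound 3 (within the scatter). For this one pair, then, the read-out does not separate the two groups, even though the leaving group brings a five-membered aromatic ring and 2 hydrogen-bond acceptors and the entering group brings neither. Nothing available here gives a reason for this outcome.

As far as these compounds go, it remains open whether other groups at this place, such as an amine, a carboxylic acid or a longer carbon chain, would also stay within the scatter of compound 2. From the compounds shown here alone, it is equally open whether this exchange would give a similar step if the methoxy group on the shared core were replaced by another group.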